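The source may hold more compounds than are shown below. What is called first, only, known or untested is meant among the compounds shown, and "the series" means these compounds.

Measured so far in a functional assay on the whole organism with Mus musculus as the target, in the writhing test; on this read-out lower numbers stand for an effect already at smaller amounts and higher numbers for an effect only at larger amounts of compound:
compound 1, `CCOC(=O)Cc1nn(C)c2oc(=O)cc(C)c12`, gives > 100 mg/kg.
compound 2, `Cc1cc(O)oc2nnc(CC(=O)O)c1-2`, gives > 100 mg/kg.

The value of compound 1 is a limit of the assay, not a number. The value of compound 2 is likewise a limit of the assay. Among the compounds with values here, compound 2 therefore stands at no fixed point on the scale: only a limit is known for it, and the one other value in this assay is a limit as well. Both values sit at the limit of > 100 mg/kg in this assay, at which 2 of the 2 values shown sit. Within the data shown here, no pair of measured compounds that differ in one place exists, so no measured step is available.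

Compound 3, `CCOC(=O)Cc1nnc2oc(O)cc(C)c1-2`, is not yet measured in this assay. It differs from compound 2 by ethyl in place of hydrogen on an oxygen next to a carbonyl group; cut one bond further out, the change reads hydroxy to ethoxy, carboxy to ethoxycarbonyl. Without a measured step, no direction can be supported. The step that the limit leaves unreadable from compound 2 to compound 3 is expected to amount to nothing beyond the scatter, and the outcome is most likely once more a limit. Compound 3 is estimated at 150 mg/kg, with a range from 40 mg/kg to 600 mg/kg.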

Compound 3, dose for half-maximal effect: > 100 mg/kg
Compound 3 was reported as a limit (the forecaster's own chance of this, stated with the estimate: 75%); the middle value lies beyond the limit too.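

In this assay compound 3 gives > 100 mg/kg as a limit of the assay, not a number. No step can be read between compound 2 and compound 3, since both stand at the same limit: the limit of > 100 mg/kg in this assay, at which 3 of the 3 values shown sit. On these data alone, whether ethyl in place of hydrogen, or any other change to these compounds, alters the effect in this assay stays open.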